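Swapping an Aromatic Ring for a Saturated One

The source may hold more compounds than are shown below. What is called first, only, known or untested is meant among the compounds shown, and "the series" means these compounds.

In an assay on isolated protein for activation of cGMP-dependent protein kinase 1 (Homo sapiens), read by ADP-Glo, with stated times of 30 min and 2 h, in the presence of a further agent that is not named here (on this read-out lower numbers stand for an effect already at smaller amounts and higher numbers for an effect only at larger amounts of compound), three related compounds have been measured. Compound 1 `O=C(O)c1ccc2nc(CN3CCC[C@H](O[C@H](CO)c4cc(Cl)cc(Cl)c4)[C@@H]3c3ccccc3)[nH]c2c1` gives 380 nM, compound 2 `Nc1cc(C(=O)O)ccc1CN1CCC[C@H](O[C@H](CO)c2cc(Cl)cc(Cl)c2)[C@@H]1c1ccccc1` gives 290 nM, and compound 3 `Cc1cc(C(=O)O)ccc1CN1CCC[C@H](O[C@H](CO)c2cc(Cl)cc(Cl)c2)[C@@H]1c1ccccc1F` gives 2600 nM, the highest of the three numbers, beyond the scatter from both others, with compound 1 nearer and compound 2 further away. Going by the values given here, the only measured step, a 1.3-fold lower number from compound 1 to compound 2 (0.12 log units; within the scatter), concerns a different part of the shared core and so does not speak to the change now in question. Compound 4 `Cc1cc(C(=O)O)ccc1CN1CCC[C@H](O[C@H](CO)c2cc(Cl)cc(Cl)c2)[C@@H]1C1CCCCC1` differs from compound 3 in one place: cyclohexyl in place of 2-fluorophenyl on a saturated ring carbon. Among the compounds with values here, no measured pair shows this kind of change, so neither direction is supported. Compound 4 is therefore expected to give about 2500 nM, with a range from 800 nM to 8000 nM. This expectation corresponds to a step of a 1.0-fold lower number from compound 3 to compound 4 (0.02 log units; within the scatter), expected to stay within the scatter.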

Compound 4, half-maximal effective concentration: 65000 nM
Compound 4: the middle estimate sits 26-fold (1.41 log units) below what was measured, and the stated range ends below it.
By their numbers in this assay, from the lowest: compounds 2 and 1 (each within the scatter of the next); then compound 3; then compound 4.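

Going by these compounds alone, on the saturated ring carbon next to the ring nitrogen, replacing 2-fluorophenyl with cyclohexyl brings a 25-fold higher number from compound 3 to compound 4 (1.40 log units; beyond the scatter) in this assay, so this is the first sign that the group at this carbon strongly affects the result. An aromatic ring and a non-aromatic ring of similar size are clearly not interchangeable here. No available measurement explains this step. The change removes both the aromatic ring and the fluorine, and the compounds shown do not separate the two. Going by these compounds, how a pyridyl or cyclopentyl group would behave at this carbon also remains open.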